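This account rests on a few compounds, and the source may have more. Where it says the series, first, only, none or still open, it means among the compounds named here.

Measured in an ADME assay on L1210/0 cells (Mus musculus) for cytotoxicity, with a stated time of 48 h; on this read-out higher numbers stand for weaker inhibition and lower numbers for stronger inhibition:

- compound 1 `CO[C@@H]1OC[C@@H](OC(C)=O)[C@@H](OC(C)=O)[C@]1(F)n1ccc(=O)[nH]c1=O`: 55000 nM
- compound 2 `Nc1ncnc2c1ncn2C1CC(O)C(/C=N/O)O1`: 17400 nM
- compound 3 `CN(C)c1ncnc2c1ncn2COCCO`: > 200000 nM

The read-out is the concentration that cuts cell growth by half, so a smaller number means a stronger effect on the cells. Compound 1 gives 55000 nM and compound 2 gives 17400 nM, so compound 2 needs the lower concentration of these two.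

Compound 3 gives > 200000 nM, which is a limit of the assay and not a number. This set therefore contains (the limit of > 200000 nM in this assay, at which 1 of the 3 values shown sits). All that can be said is where compound 3 stands against that limit, not how far beyond it the true value lies.

Compound 4 `OCCOCn1cnc2c(O)ncnc21` differs from compound 3 in one place: hydroxy in place of dimethylamino on an aromatic carbon. Among the measured compounds shown here, no measured pair here shows what this swap does, so there is no direct guide to its size.

No step beyond the scatter is expected, because compound 3 gives > 200000 nM, and nothing measured here points to a clear gain in strength. The expected change is a number no higher from compound 3 to compound 4 (the limit leaves the size open). For compound 4 the estimated value is 200000 nM, with an expected range from 70000 nM to 500000 nM.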

Compound 4, half-maximal inhibitory concentration: > 200000 nM
Compound 4 ended at the assay's limit (the forecaster's own chance of this, stated with the estimate: 65%); the middle value sits exactly at the limit.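

No step from compound 3 to compound 4 can be read, because both rest on the same limit of the assay and not on numbers: the limit of > 200000 nM in this assay, at which 2 of the 4 values shown sit.

The compounds shown leave open how far past that limit the true values lie, and so whether hydroxy in place of dimethylamino on an aromatic carbon changes the effect on the cells at all.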